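The source may hold more compounds than are shown below. What is called first, only, known or untested is meant among the compounds shown, and "the series" means these compounds.

Working notes on the series. Compound 1 `Cc1ccc(NC(=S)NC(=O)c2ccc(OCc3ccccc3)cc2)cc1-c1nc2ccccc2[nH]1` is the weakest of the three measured compounds in a functional assay on MNK45 cells (Homo sapiens) for inhibition, read by MTT assay, with a stated time of 48 h (a higher number here means a weaker inhibitor, a lower number a stronger inhibitor), giving 57800 nM. Compound 2 `Cc1ccc(NC(=S)NC(=O)c2ccc(OCc3ccccc3F)cc2)cc1-c1nc2ccccc2[nH]1` gives 2420 nM in this assay, while compound 3 `Cc1ccc(COc2ccc(C(=O)NC(=S)Nc3ccc(C)c(-c4nc5ccccc5[nH]4)c3)cc2)cc1` gives 11300 nM. Both substituted benzyl analogues lie well beyond the scatter from compound 1: the step of a 24-fold lower number from compound 1 to compound 2 (1.38 log units; beyond the scatter) is large, with fluoro in place of hydrogen on an aromatic carbon, and the step of a 5.1-fold lower number from compound 1 to compound 3 (0.71 log units; beyond the scatter) is modest, with methyl in place of hydrogen on an aromatic carbon. Between the two substituted compounds the step of a 4.7-fold higher number from compound 2 to compound 3 (0.67 log units; beyond the scatter) is also modest.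

Compound 4 `Cc1ccc(NC(=S)NC(=O)c2ccc(OCc3ccccc3Cl)cc2)cc1-c1nc2ccccc2[nH]1` differs from compound 1 in one place: chloro in place of hydrogen on an aromatic carbon. Among the compounds with values here, the closest precedent is the step from compound 1 to compound 2, which puts a halogen at the same place, ortho to a large group, and lowers the number strongly. The methyl step from compound 1 to compound 3 points the same way but less far. A large drop in the number is therefore expected for compound 4, the step of a 17-fold lower number from compound 1 to compound 4 (1.22 log units; beyond the scatter) being the estimate, with the uncertainty set mainly by the gap between the fluoro and methyl steps. For compound 4 the expected value in this assay is 3500 nM, with a range from 900 nM to 14000 nM.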

Compound 4, half-maximal inhibitory concentration: 51400 nM
Beside the measured number, compound 4's estimate is 15-fold (1.17 log units) below it; measured number outside the range, above it.
By their numbers in this assay, from the lowest: compound 2; then compound 3; then compounds 4 and 1 (each within the scatter of the next).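

At this place, ortho to a large group, chloro gives no step beyond the scatter in this assay (a 1.1-fold lower number from compound 1 to compound 4 (0.05 log units; within the scatter)), whereas the exchange of one halogen for the other is large (a 21-fold higher number from compound 2 to compound 4 (1.33 log units; beyond the scatter)), so among the compounds shown the gain belongs to the 2-fluorobenzyl group of compound 2 and not to halogens at this place in general, with compound 4 going against any such pattern. The 2-chlorophenyl group of compound 4 also gives a weaker result than the 4-methylphenyl group of compound 3 (a 4.5-fold higher number from compound 3 to compound 4 (0.66 log units; beyond the scatter)), although that step changes both the group and its place on the ring and so cannot rank the two substituents at a single place. Nothing in the available data accounts for the gap between fluoro and chloro at this place.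

Going by these compounds, whether methyl, methoxy, hydroxyl or nitrile at this same place would follow fluoro or chloro remains open. Also open, on these data alone, is how fluoro and chloro would behave elsewhere on the ring, and whether an amine or a carboxylic acid on the benzyl ring would be tolerated.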